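Swapping the aryl group of compound 3 for methylpiperazine

This account rests on a few compounds, and the source may have more. Where it says the series, first, only, none or still open, it means among the compounds named here.

Measured in a functional assay on HepG2 cells (Homo sapiens) for inhibition, read by MTT assay, with a stated time of 72 h; a higher number here means a weaker inhibitor, a lower number a stronger inhibitor:
compound 1 `CC(C)(C)n1cc2c(n1)C(=O)CC1(CCN(C(=O)c3cc(-c4ccc(Br)cc4)nc4ccccc34)CC1)O2`: 820 nM
compound 2 `COc1ccc(-c2cc(C(=O)N3CCC4(CC3)CC(=O)c3nn(C(C)(C)C)cc3O4)c3ccccc3n2)cc1`: 2780 nM
compound 3 `CN(C)c1ccc(-c2cc(C(=O)N3CCC4(CC3)CC(=O)c3nn(C(C)(C)C)cc3O4)c3ccccc3n2)cc1`: 1730 nM

Among these three numbers, compound 3 stands apart from compound 1 only. The data show a 2.1-fold higher number from compound 1 to compound 3 (0.32 log units; beyond the scatter), while a 1.6-fold lower number from compound 2 to compound 3 (0.21 log units; within the scatter) shows no separation from compound 2.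

The next compound is compound 4 `CN1CCN(c2cc(C(=O)N3CCC4(CC3)CC(=O)c3nn(C(C)(C)C)cc3O4)c3ccccc3n2)CC1`. It carries 4-methylpiperazin-1-yl in place of 4-(dimethylamino)phenyl on an aromatic carbon, next to the ring nitrogen (4-methylpiperazin-1-yl in place of 4-(dimethylamino)phenyl on an aromatic carbon).

The nearest evidence is thin. The measured series shows a 3.4-fold higher number from compound 1 to compound 2 (0.53 log units; beyond the scatter) and a 2.1-fold higher number from compound 1 to compound 3 (0.32 log units; beyond the scatter), both modest, but these steps only exchange a group on the aromatic carbon of the retained phenyl. Going by the values given here, no measured compound loses that phenyl, so the data do not fix the direction of this larger change. A modest step towards a higher number is tentatively expected in this assay. The estimated change is a 1.7-fold higher number from compound 3 to compound 4 (0.24 log units; within the scatter). For compound 4, the expected value is 3000 nM, with an estimated range of 1000 nM to 9000 nM.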

Compound 4, half-maximal inhibitory concentration: 9550 nM
Compound 4: middle estimate off by 3.2-fold (0.50 log units), on the low side, outside the stated range (above it).
By their numbers in this assay, from the lowest: compound 1; then compounds 3 and 2 (each within the scatter of the next); then compound 4.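

In this assay, going by these compounds alone, replacing the whole aryl group at this position, rather than only the group on its phenyl ring, gives a 5.5-fold higher number from compound 3 to compound 4 (0.74 log units; beyond the scatter) and a 3.4-fold higher number from compound 2 to compound 4 (0.54 log units; beyond the scatter), while a 12-fold higher number from compound 1 to compound 4 (1.07 log units; beyond the scatter) is the only large step. All three aryl compounds therefore have lower numbers than compound 4, whichever group their phenyl ring carries. Nothing available explains this rise.

On these data alone, it remains open whether the higher number follows from losing the aromatic ring on this carbon or from the 4-methylpiperazin-1-yl group itself. A morpholine or a plain piperidine at this position, or a phenyl ring carrying the same methylpiperazine, would help separate these two readings.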